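Taking the methyl off compound 3

This account rests on a few compounds, and the source may have more. Where it says the series, first, only, none or still open, it means among the compounds named here.

In a functional assay on HT-29 cells (Homo sapiens) for antiproliferative activity, read by sulforhodamine B assay, with a stated time of 72 h (on this read-out higher numbers stand for weaker inhibition and lower numbers for stronger inhibition), the three measured compounds share one core. Compound 1 `N#Cc1ccc(NC(=S)N/N=C/c2ccc3ccccc3n2)cc1` stands at 15600 nM and compound 2 `S=C(N/N=C/c1ccc2ccccc2n1)Nc1ccc(Cl)cc1` at 97200 nM while compound 3 `Cc1ccccc1NC(=S)N/N=C/c1ccc2ccccc2n1` reads 42300 nM as the second highest of the three numbers. Its nearest neighbour on the numbers is compound 2 and its furthest is compound 1.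

Among the measured compounds shown here, compound 4 `S=C(N/N=C/c1ccc2ccccc2n1)Nc1ccccc1` follows from compound 3 with hydrogen in place of methyl on an aromatic carbon and no measured step makes this exact change. The closest evidence is a 2.7-fold higher number from compound 1 to compound 3 (0.43 log units; beyond the scatter) together with a 2.3-fold lower number from compound 2 to compound 3 (0.36 log units; beyond the scatter) and a 6.2-fold higher number from compound 1 to compound 2 (0.79 log units; beyond the scatter) as the widest of the three. All three are modest steps beyond the scatter. They exchange whole substituted phenyl groups or a ring substituent, and the numbers of compound 1 and compound 2 lie on either side of compound 3, so they fix no direction for the loss of the methyl.

The central expectation in this assay is therefore no step beyond the scatter, with a modest step in either direction still possible. The estimated step is a 1.1-fold lower number from compound 3 to compound 4 (0.05 log units; within the scatter) for the central value. For compound 4 the estimated value is 38000 nM with an expected range from 15000 nM to 95000 nM as the working figures.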

Compound 4, half-maximal inhibitory concentration: 17000 nM
Compound 4: the middle estimate sits 2.2-fold (0.35 log units) above what was measured, within the range that was stated.
By their numbers in this assay, from the lowest: compounds 1 and 4 (each within the scatter of the next); then compound 3; then compound 2.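

In this assay, the loss of the methyl ortho to a large group gives a 2.5-fold lower number from compound 3 to compound 4 (0.40 log units; beyond the scatter), so this single change, 2-methylphenyl to phenyl, moves the read-out towards stronger inhibition, a direction the earlier exchanges of whole substituted phenyl groups could not fix. Compound 4 also provides an unsubstituted reference for the other two compounds: hydrogen in place of chloro gives a 5.7-fold lower number from compound 2 to compound 4 (0.76 log units; beyond the scatter), whereas hydrogen in place of cyano gives a 1.1-fold higher number from compound 1 to compound 4 (0.04 log units; within the scatter). Among the compounds shown, methyl and chloro therefore go with weaker inhibition than hydrogen, while cyano is the exception, and no substituent shown gives a number beyond the scatter below that of compound 4.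

No measurement shown here bears on why these substituents differ in this way. Going by these compounds, it remains open whether a methoxy group, an amine, a carboxylic acid or a longer chain on this phenyl ring would give a lower number than compound 4, and whether the methyl would have the same effect elsewhere on the ring.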